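Swapping a Bromophenyl for Thiophene in a Cytotoxicity Series

This account rests on a few compounds, and the source may have more. Where it says the series, first, only, none or still open, it means among the compounds named here.

Of the compounds shown here, three sharing one core have been tested in an ADME assay on MRC5 cells (Homo sapiens) for cytotoxicity, read by MTT assay, with a stated time of 24 h; on this read-out lower numbers stand for stronger inhibition and higher numbers for weaker inhibition. Compound 1 `CCOC(=O)c1c(C)[nH]c(=O)c(C#N)c1-c1ccc(OC)cc1` gives 192000 nM, compound 2 `CCOC(=O)c1c(C)[nH]c(=O)c(C#N)c1-c1ccc([N+](=O)[O-])cc1` gives 2230000 nM, and compound 3 `CCOC(=O)c1c(C)[nH]c(=O)c(C#N)c1-c1ccc(Br)cc1` gives 310000 nM. Compound 3 stands second highest of the three, close to compound 1 and well apart from compound 2. The measured steps each swap one group on the phenyl ring: a 12-fold higher number from compound 1 to compound 2 (1.07 log units; beyond the scatter), a 1.6-fold higher number from compound 1 to compound 3 (0.21 log units; within the scatter), and a 7.2-fold lower number from compound 2 to compound 3 (0.86 log units; beyond the scatter). Compound 4 `CCOC(=O)c1c(C)[nH]c(=O)c(C#N)c1-c1cccs1` differs from compound 3 in another way: thiophen-2-yl in place of 4-bromophenyl on an aromatic carbon. Among the compounds with values here, no measured step trades the whole phenyl ring for another ring, so the guidance is loose; bromo against methoxy stayed within the scatter, and only nitro moved the number far. Compound 4 is therefore expected to stay near compound 3, with a step of about a 1.2-fold lower number from compound 3 to compound 4 (0.08 log units; within the scatter) in this assay. The estimate for compound 4 is 260000 nM, in a range from 100000 nM to 700000 nM.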

Compound 4, half-maximal inhibitory concentration: 205000 nM
Estimate against measurement, compound 4: 1.3-fold (0.10 log units) above; measured number inside the range.
By their numbers in this assay, from the lowest: compounds 1, 4 and 3 (each within the scatter of the next); then compound 2.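

Replacing the whole ring at this position gives a 1.5-fold lower number from compound 3 to compound 4 (0.18 log units; within the scatter) in this assay, so thiophen-2-yl, a five-membered aromatic ring with 1 hetero atom, cannot be told apart here from 4-bromophenyl. For these two groups, then, the read-out does not depend on keeping a six-membered ring of carbon only. No measurement at hand explains this result.

Still open, as far as these compounds go, is whether a phenyl ring carrying an amine or a carboxylic acid would stay near compound 3 or move as far as compound 2. From the compounds shown here alone, a longer alkyl chain in place of the ring is equally open.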